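The source may hold more compounds than are shown below. What is called first, only, known or untested is meant among the compounds shown, and "the series" means these compounds.

Measured so far in a functional assay on HOS-TE85 cells (Homo sapiens) for inhibition, read by CCK-8 assay, with a stated time of 72 h; on this read-out lower numbers stand for stronger inhibition and higher numbers for weaker inhibition: compound 1 `COc1ccccc1N1C(=O)CSC1c1cccc(C(=O)NCCCCc2ccc(Cl)cc2)c1` gives 78.6 nM; compound 2 `O=C(NCCCCc1ccccc1)c1cccc(C2SCC(=O)N2c2cccc(F)c2)c1` gives 32.4 nM; compound 3 `COc1cc(F)ccc1N1C(=O)CSC1c1cccc(C(=O)NCCCCc2ccccc2)c1` gives 71.1 nM.

Compound 3 holds the second highest of the three numbers; compound 1 sits within the scatter of it, while compound 2 lies lower, the gap being a 2.2-fold higher number from compound 2 to compound 3 (0.34 log units; beyond the scatter).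

Compound 4 `O=C(NCCCCc1ccccc1)c1cccc(C2SCC(=O)N2c2ccccc2F)c1` differs from compound 3 by 2-fluorophenyl in place of 4-fluoro-2-methoxyphenyl on an amide-type nitrogen in a ring. Within the data shown here, the only step that bears on this change is a 2.2-fold higher number from compound 2 to compound 3 (0.34 log units; beyond the scatter), which replaced a plain fluorophenyl with the 4-fluoro-2-methoxyphenyl now leaving. Returning to a fluorophenyl without the methoxy group is therefore expected to roughly undo that step, a modest drop toward the number of compound 2.

Compound 4 is expected at 40 nM, range 20 nM to 90 nM, a step of a 1.8-fold lower number from compound 3 to compound 4 (0.25 log units; within the scatter).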

Compound 4, half-maximal inhibitory concentration: 34.1 nM
Compound 4: middle estimate off by 1.2-fold (0.07 log units), on the high side, and the stated range covers the measured number.
By their numbers in this assay, from the lowest: compounds 2 and 4 (each within the scatter of the next); then compounds 3 and 1 (each within the scatter of the next).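

On the amide-type nitrogen in the ring, 2-fluorophenyl in place of 4-fluoro-2-methoxyphenyl gives a 2.1-fold lower number from compound 3 to compound 4 (0.32 log units; beyond the scatter), while 2-fluorophenyl in place of 3-fluorophenyl gives a 1.1-fold higher number from compound 2 to compound 4 (0.02 log units; within the scatter). The two fluorophenyl groups therefore cannot be told apart on this read-out, and 4-fluoro-2-methoxyphenyl stands apart from both. No measurement shown accounts for this difference.

The compounds shown do not separate the contribution of the methoxy group from that of the 4-fluoro placement. As far as these compounds go, how an amine or a carboxylic acid on this phenyl ring would read remains open.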